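The source may hold more compounds than are shown below. What is called first, only, known or untested is meant among the compounds shown, and "the series" means these compounds.

In a functional assay on Raji cells (Homo sapiens) for antiproliferative activity, read by MTT assay, with a stated time of 48 h (on this read-out lower numbers stand for stronger inhibition and higher numbers for weaker inhibition), compound 1 `CCN(CC)CCn1c(N)c(-c2nc3ccccc3[nH]2)c2nc(C#N)c(C#N)nc21`, which carries a diethylamino group on its chain, gives 8950 nM. Compound 2 `CCCn1c(N)c(-c2nc3ccccc3[nH]2)c2nc(C#N)c(C#N)nc21`, with a plain propyl chain on the same core, gives > 50000 nM. That reading is a limit of the assay and not a number, so compound 2 has no exact position on the scale. Among the compounds with values here, the one measured step that bears on the next compound is an at least 5.5-fold higher number from compound 1 to compound 2 (0.74 log units; beyond the scatter), made by methyl in place of diethylamino on a saturated chain carbon, two bonds along the chain from an aromatic nitrogen. Compound 3 `CN(C)CCCn1c(N)c(-c2nc3ccccc3[nH]2)c2nc(C#N)c(C#N)nc21` departs from compound 2 by dimethylamino in place of hydrogen on a saturated chain carbon, three bonds along the chain from an aromatic nitrogen, turning propyl into 3-(dimethylamino)propyl. This change puts an amino group back on the chain and so runs opposite to the measured step, although the chain and the amino group are not those of compound 1. A lower number is therefore expected in this assay, of a size similar to that step. The expected change is an at least 5.0-fold lower number from compound 2 to compound 3 (0.69 log units; beyond the scatter). For compound 3 the estimate is 10000 nM, with an expected range of 3000 nM to 35000 nM.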

Compound 3, half-maximal inhibitory concentration: 1230 nM
Compound 3: the middle estimate sits 8.1-fold (0.91 log units) above what was measured, and the stated range ends above it.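

In this assay, the change from propyl to 3-(dimethylamino)propyl gives an at least 40-fold lower number from compound 2 to compound 3 (1.60 log units; beyond the scatter), so a second amino-bearing chain on the shared core also stands clear of the plain propyl chain, which the diethylamino chain alone could not show. The two chains that carry an amine also differ from each other, with a 7.3-fold lower number from compound 1 to compound 3 (0.86 log units; beyond the scatter), so the kind of amine on the chain matters to the number, or its distance from the aromatic nitrogen does, or both; this single change of (dimethylamino)methyl in place of diethylamino cannot tell these apart. The size of the step from the propyl compound remains a floor and not a measured gap, since compound 2 stands at a limit and not at a number: the limit of > 50000 nM in this assay, at which 1 of the 3 values shown sits.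

The compounds shown leave open how much of that difference belongs to the chain and how much to the amine, which a 2-(dimethylamino)ethyl or a 3-(diethylamino)propyl chain would separate. They also leave open whether a chain ending in a piperidine, a primary amine or a hydroxyl group would read like compound 3.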